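Aryl substituent change in a piperazine series

The compounds below may be only part of what the source reports. "The series", "measured", "known", "first", "only" and "open" are said of these compounds alone.

Two compounds of the series have numbers in an assay on isolated protein for binding affinity to Adrenergic receptor alpha-1 (Rattus norvegicus), read by radioligand binding; on this read-out lower numbers stand for stronger inhibition and higher numbers for weaker inhibition. Compound 1 `O=C1C2CCCN2C(=O)N1CN1CCN(c2ccccc2)CC1` gives 1000 nM and compound 2 `O=C1C2CCCN2C(=O)N1CN1CCN(c2cccc(Cl)c2)CC1` gives 292 nM. For the measured compounds named here, the one step between them, a 3.4-fold lower number from compound 1 to compound 2 (0.53 log units; beyond the scatter), puts compound 2 at the lower of the two numbers. Compound 3 `O=C1C2CCCN2C(=O)N1CN1CCN(c2cccc(C(F)(F)F)c2)CC1` is the next member; its change from compound 2 is trifluoromethyl in place of chloro on an aromatic carbon, on an aromatic carbon. Going by the values given here, no step between a chloro and a trifluoromethyl group has been measured, so the only bearing step is the one from compound 1 to compound 2, which shows that this aromatic position tolerates a halogen with a modest gain. For compound 3 no step beyond the scatter is expected, a 1.2-fold higher number from compound 2 to compound 3 (0.08 log units; within the scatter). The estimate for compound 3 in this assay is 350 nM, with a range from 120 nM to 1000 nM.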

Compound 3, inhibition constant: > 1000 nM
Compound 3 gave a limit, no number; the forecaster's own chance of this, stated with the estimate: 5%; at least 2.8-fold (0.45 log units) between middle value and limit.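

In this assay, chloro and trifluoromethyl are not interchangeable on this aromatic carbon, meta to a large group, with an at least 3.4-fold higher number from compound 2 to compound 3 (0.53 log units; beyond the scatter). Compound 3 gives a limit of the assay and not a number: the limit of > 1000 nM in this assay, at which 1 of the 3 values shown sits. The gain seen with chloro does not carry over to trifluoromethyl, so this position does not accept every replacement for hydrogen alike; for trifluoromethyl in place of hydrogen the data give only a number no lower from compound 1 to compound 3 (the limit leaves the size open) and no size that can be read.

From the compounds shown here alone, how far compound 3 lies past the limit stays open, as does any reading of trifluoromethyl against hydrogen. Also open, going by these compounds, is how a methoxy, an amine or a carboxylic acid at this position would read in this assay.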